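Fluoro in Place of Methoxy: An Expectation for Compound 4

The source may hold more compounds than are shown below. What is called first, only, known or untested is meant among the compounds shown, and "the series" means these compounds.

Compound 1, `C#CCN(CCCCOc1ccc2ccc(=O)oc2c1)Cc1cccc(OC)c1`, gives 78600 nM in an ADME assay on isolated protein for inhibition of Amine oxidase [flavin-containing] A (Homo sapiens), read by fluorescence and Amplex Red, with stated times of 15 min and 20 min; a higher number here means a weaker inhibitor, a lower number a stronger inhibitor.
Compound 2, `C#CCN(CCCCOc1ccc2ccc(=O)oc2c1)Cc1cccc(F)c1`, gives 69200 nM.
Compound 3, `C#CCN(CCCOc1ccc2ccc(=O)oc2c1)Cc1cccc(OC)c1`, gives 22700 nM.

Compound 1 and compound 2 differ in one place only: fluoro in place of methoxy on an aromatic carbon. That change made a step of a 1.1-fold lower number from compound 1 to compound 2 (0.06 log units; within the scatter), so the two numbers cannot be told apart. Compound 3 differs from compound 1 in more than one place; the difference between the two cores is not broken down here. Compound 3 has the lowest number of the three, and its gaps to compound 1 and compound 2 are both beyond the usual scatter.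

Compound 4, `C#CCN(CCCOc1ccc2ccc(=O)oc2c1)Cc1cccc(F)c1`, has not yet been measured. It differs from compound 3 by fluoro in place of methoxy on an aromatic carbon, the same change seen between compound 1 and compound 2, at a place described in the same words. Because the earlier step was a 1.1-fold lower number from compound 1 to compound 2 (0.06 log units; within the scatter), a similarly small step is expected here, estimated as a 1.1-fold lower number from compound 3 to compound 4 (0.05 log units; within the scatter). Compound 4 is therefore expected to give about 20000 nM, most likely between 8000 nM and 50000 nM.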

Compound 4, half-maximal inhibitory concentration: 29300 nM
Compound 4: the middle estimate sits 1.5-fold (0.17 log units) below what was measured; the range from low to high includes it.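

In this assay putting fluoro in place of methoxy on an aromatic carbon gave a 1.3-fold higher number from compound 3 to compound 4 (0.11 log units; within the scatter) and so made no readable change on this second core. The swap therefore carried over from one core to the other, with both steps small and no readable difference between them: the same change on two cores in this assay, a 1.1-fold lower number (0.06 log units; within the scatter) from compound 1 to compound 2 and a 1.3-fold higher number (0.11 log units; within the scatter) from compound 3 to compound 4, 1.5-fold (0.17 log units) apart, within the scatter of two such steps. Within the data shown here, this rests on only two pairs of compounds, so it does not show that the swap would stay this small on any other core, and it does not explain why methoxy and fluoro read alike in these pairs.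

The compounds shown leave open whether other groups at this place on the ring, such as chloro, trifluoromethyl or a nitrile, would also leave the number unchanged within the scatter. They also leave open whether the swap would stay this small with a longer chain or with fluoro or methoxy at another place on the ring.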